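Methoxy in place of methyl beside an ethynyl-bearing core

The compounds below may be only part of what the source reports. "The series", "measured", "known", "first", "only" and "open" are said of these compounds alone.

Measured compounds:
compound 1 `Cc1ncnc2c1c(I)cn2[C@@H]1O[C@H](CO)[C@@H](O)[C@H]1O` gives 4720 nM;
compound 2 `C#Cc1cn([C@@H]2O[C@H](CO)[C@@H](O)[C@H]2O)c2ncnc(C)c12` gives > 20000 nM;
compound 3 `Cc1ncnc2c1c(-c1ccoc1)cn2[C@@H]1O[C@H](CO)[C@@H](O)[C@H]1O` gives > 20000 nM.

Among the measured compounds shown here, compound 1 is the only compound that gives a number in a functional assay on HCT-116 cells (Homo sapiens), read by MTT assay, with a stated time of 72 h; on this read-out lower numbers stand for stronger inhibition and higher numbers for weaker inhibition. Compound 2 sits at a limit of this assay, > 20000 nM, not at a number. Compound 3 likewise sits at a limit, > 20000 nM. The two measured steps that have a readable size both start from compound 1: an at least 4.2-fold higher number from compound 1 to compound 2 (0.62 log units; beyond the scatter) and an at least 4.2-fold higher number from compound 1 to compound 3 (0.62 log units; beyond the scatter); the step that the two limits leave unreadable from compound 2 to compound 3 cannot be sized, since the limit of > 20000 nM in this assay, at which 2 of the 3 values shown sit, holds two of the three values.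

Compound 4 `C#Cc1cn([C@@H]2O[C@H](CO)[C@@H](O)[C@H]2O)c2ncnc(OC)c12` differs from compound 2 in one place: methoxy in place of methyl on an aromatic carbon. For the measured compounds named here, none of the measured steps touches this position; all three concern the group on the five-membered ring. There is therefore no measured basis for a direction. Since compound 2 already sits at the limit > 20000 nM, compound 4 is expected to sit there as well, with a step that the limit leaves unreadable from compound 2 to compound 4. The estimate for compound 4 is 25000 nM, in a range from 8000 nM to 80000 nM, most likely reported only as a limit.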

Compound 4, half-maximal inhibitory concentration: 4060 nM
Compound 4: the middle estimate sits 6.2-fold (0.79 log units) above what was measured; measured number outside the range, below it.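

Until this point, only the group on the five-membered ring had been varied. With ethynyl held in place, methoxy in place of methyl on the aromatic carbon next to the ring nitrogen gives an at least 4.9-fold lower number from compound 2 to compound 4 (0.69 log units; beyond the scatter) in this assay, so this position on the six-membered ring also bears on the read-out. The full size of the step cannot be read because one of its ends is a limit and not a number: the limit of > 20000 nM in this assay, at which 2 of the 4 values shown sit.

The compounds shown leave open whether methoxy has the same effect alongside iodo or furan-3-yl, and whether the oxygen of methoxy or simply the larger group accounts for the step. They also leave open whether an amine, an ethyl group or a longer alkoxy chain on this carbon would give a lower or a higher number.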